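A few compounds are considered here, and "the series" means these few. Any claim that something is new, unique, unknown or untested is made for them only; others in the source may bear on it.

In a functional assay on HeLa cells (Homo sapiens) for inhibition, read by CCK-8 assay, with a stated time of 48 h (on this read-out higher numbers stand for weaker inhibition and lower numbers for stronger inhibition), compound 2 (`Cc1cc(C)cc(NC(=O)NCCNS(=O)(=O)c2ccc(-c3ccccc3OCc3ccccc3)s2)c1`) gives > 50000 nM, which is a limit and not a number. Compound 2 thus stands at the limit of > 50000 nM in this assay, at which 1 of the 3 values shown sits.

Compound 4 (`Cc1cc(C)cc(NC(=O)NCCNS(=O)(=O)c2ccc(-c3ccccc3OCc3cccc(O)c3)s2)c1`) differs from it by one change, (hydroxy in place of hydrogen on an aromatic carbon), turning benzyloxy to (3-hydroxybenzyl)oxy. Among the compounds with values here, the one measured step, an at least 7.1-fold lower number from compound 2 to compound 3 (0.85 log units; beyond the scatter), alters a group on an amine nitrogen instead, so it does not test the hydroxy.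

The nearest hint comes from compound 1 (`O=S(=O)(NCCNC(=S)Nc1cccc(Cl)c1)c1ccc(-c2ccccc2OCc2cccc(O)c2)s1`), which has the hydroxy and gives 10700 nM. Compound 3 (`O=S(=O)(NCCNC(=S)Nc1ccc(Cl)cc1)c1ccc(-c2ccccc2OCc2ccccc2)s1`) lacks it and gives 7000 nM. These two values lie within the usual scatter of each other, although the two compounds also differ elsewhere.

No change beyond the scatter is therefore expected in this assay, and the expected result is an at least 1.1-fold lower number from compound 2 to compound 4 (0.04 log units; that floor lies within the scatter). For compound 4 the estimated value is 45000 nM, with an expected range of 18000 nM to 90000 nM.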

Compound 4, half-maximal inhibitory concentration: > 20000 nM
Compound 4: a limit, no number (the forecaster's own chance of this, stated with the estimate: 60%); the middle value does not contradict the limit.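

Compound 4 gives > 20000 nM in this assay, which is a limit and not a number. Compound 2 also carries a limit, so the step from hydroxy to hydrogen on this aromatic carbon cannot be read in either direction. Changing the group on the amine nitrogen gives an at least 1.8-fold higher number from compound 1 to compound 4 (0.27 log units; that floor lies within the scatter), a floor that does not by itself separate compound 1 from compound 4.

Going by these compounds, the effect of this hydroxy in a compound with a measured number stays open. So does whether a methoxy or an amine at this place would give a number.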